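Cyano for trifluoromethyl on the amide aryl ring

A few compounds are considered here, and "the series" means these few. Any claim that something is new, unique, unknown or untested is made for them only; others in the source may bear on it.

Compound 1 `CCCC(C)C(=O)Nc1c(C(O)(C(F)(F)F)C(F)(F)F)ccc2ccccc12` carries a 1-methylbutyl group on the carbonyl carbon. In an assay on LtK cells with ATP-sensitive inward rectifier potassium channel 11 (Homo sapiens) as the target (a lower number here means that less compound is needed, a higher number that more compound is needed for the effect), compound 1 gives only a limit, > 10000 nM. Compound 2 `O=C(Nc1c(C(O)(C(F)(F)F)C(F)(F)F)ccc2ccccc12)c1cccc(C(F)(F)F)c1` carries 3-(trifluoromethyl)phenyl in its place, and in this assay compound 2 gives 84 nM. The step is an at least 110-fold lower number from compound 1 to compound 2 (2.07 log units; beyond the scatter). For the measured compounds named here, compound 2 thus stands as the only number in the set so far; the other value is a limit, (the limit of > 10000 nM in this assay, at which 1 of the 2 values shown sits).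

Compound 3 `N#Cc1cccc(C(=O)Nc2c(C(O)(C(F)(F)F)C(F)(F)F)ccc3ccccc23)c1` differs from compound 2 by cyano in place of trifluoromethyl on an aromatic carbon. Going by the values given here, the single measured step, an at least 110-fold lower number from compound 1 to compound 2 (2.07 log units; beyond the scatter), exchanged the whole group on the carbonyl carbon and says nothing direct about swapping one substituent on the aryl ring for another; it bears on compound 3 only in that the aryl amide is kept. Among the compounds with values here, no measured pair sets cyano against trifluoromethyl. For compound 3 the step of a 1.8-fold higher number from compound 2 to compound 3 (0.25 log units; within the scatter) is therefore expected to stay within the scatter or to amount to a modest loss. Compound 3 is estimated at 150 nM, within 50 nM to 500 nM.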

Compound 3, half-maximal effective concentration: 12 nM
Compound 3: the middle estimate sits 13-fold (1.10 log units) above what was measured; measured number below the stated range.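

In this assay, the substituent on the amide aryl ring matters in its own right, not only the presence of the aryl amide: cyano in place of trifluoromethyl on this aromatic carbon gives a 7.0-fold lower number from compound 2 to compound 3 (0.85 log units; beyond the scatter). So far the only reading had been an exchange of the whole group on the carbonyl carbon; with 3-cyanophenyl in place of 1-methylbutyl, the step now reads an at least 830-fold lower number from compound 1 to compound 3 (2.92 log units; beyond the scatter). Compound 1 stands only as a limit, so this step gives a bound and not a measured size: the limit of > 10000 nM in this assay, at which 1 of the 3 values shown sits.

The compounds shown do not tell why cyano gives the lower number here, nor whether other groups on the same aromatic carbon, such as an amine, a carboxylic acid or a methoxy group, would follow it or fall back towards trifluoromethyl. Also open, as far as these compounds go, is whether the cyano step carries over to another carbon of this ring, and how an unsubstituted phenyl on the carbonyl carbon would compare with compound 2 and compound 3.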